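A few compounds are considered here, and "the series" means these few. Any claim that something is new, unique, unknown or untested is made for them only; others in the source may bear on it.

Measured compounds:
compound 1 `Nc1ccc(/C=C2\SC(=O)N(Cc3ccc(C(F)(F)F)cc3)C2=O)cc1`, 134000 nM;
compound 2 `Nc1cccc(/C=C2\SC(=O)N(Cc3ccc(F)cc3)C2=O)c1`, 140000 nM;
compound 3 `Cc1ccc(CN2C(=O)S/C(=C\c3cccc(N)c3)C2=O)cc1`, 158000 nM.

In a functional assay on FM3A cells (Mus musculus) for cytotoxicity, read by cell counting, with a stated time of 2 days (on this read-out lower numbers stand for stronger inhibition and higher numbers for weaker inhibition), compound 1 gives 134000 nM, compound 2 gives 140000 nM and compound 3 gives 158000 nM. Compound 3 carries the highest of the three numbers, but its nearest neighbour compound 2 and its furthest neighbour compound 1 both lie within the scatter of it, so the three compounds cannot be told apart on this read-out.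

Compound 4 `Nc1cccc(/C=C2\SC(=O)N(Cc3ccc(C(F)(F)F)cc3)C2=O)c1` is the next member: trifluoromethyl in place of methyl on an aromatic carbon. For the measured compounds named here, one measured step bears on this change, since it alters the same position of the same ring: a 1.1-fold higher number from compound 2 to compound 3 (0.05 log units; within the scatter). That step stayed within the scatter. Going by the values given here, compound 1, which already carries the trifluoromethyl, shows a number in the same narrow band as compound 2 and compound 3, although it differs from compound 4 in a second place and no step is available for that pair.

Compound 4 is therefore expected to stay within the scatter of compound 3, giving an estimated 1.1-fold lower number from compound 3 to compound 4 (0.04 log units; within the scatter) and an estimated value of 145000 nM, with a range from 70000 nM to 300000 nM.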

Compound 4, half-maximal inhibitory concentration: > 250000 nM
Compound 4 ended at the assay's limit; the forecaster's own chance of this, stated with the estimate: 10%; middle value at least 1.7-fold (0.23 log units) from the limit.
By their numbers in this assay, from the lowest: compounds 1, 2 and 3 (each within the scatter of the next). At a limit, above all of these: compound 4.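

The value of compound 4 is a limit of the assay and not a number: the limit of > 250000 nM in this assay, at which 1 of the 4 values shown sits. At this position, trifluoromethyl in place of methyl gives an at least 1.5-fold higher number from compound 3 to compound 4 (0.19 log units; that floor lies within the scatter), and trifluoromethyl in place of fluoro gives an at least 1.7-fold higher number from compound 2 to compound 4 (0.25 log units; that floor lies within the scatter), so this group may move the number where the swap of fluoro for methyl did not, although neither floor passes the scatter. With trifluoromethyl held constant, 3-aminophenyl in place of 4-aminophenyl gives an at least 1.8-fold higher number from compound 1 to compound 4 (0.27 log units; that floor lies within the scatter), which leaves the same doubt about whether the place of the amine matters.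

Going by these compounds, the true number of compound 4 remains unknown, so it is unsettled whether any of these steps exceeds the scatter. Also open, on these data alone, is how a chloro or methoxy group at this position would read, or a carboxylic acid in place of the amine.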